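Chain extension on two related cores: compounds 1 to 4

The source may hold more compounds than are shown below. What is called first, only, known or untested is meant among the compounds shown, and "the series" means these compounds.

Compound 1 `CCCCCn1cc(COc2ccc(/C=C/C(=O)c3cc4c(cc3O)OC(C)(C)CC4)cc2)nn1` and compound 2 `CCCCCCCCn1cc(COc2ccc(/C=C/C(=O)c3cc4c(cc3O)OC(C)(C)CC4)cc2)nn1` share a core and differ at a single place, (propyl in place of hydrogen on a saturated chain carbon, five bonds along the chain from an aromatic nitrogen). In a functional assay on HepG2 cells (Homo sapiens) for antiproliferative activity, read by MTT assay (on this read-out higher numbers stand for weaker inhibition and lower numbers for stronger inhibition), compound 1 gives 95800 nM, and compound 2 gives 127000 nM; the step of a 1.3-fold higher number from compound 1 to compound 2 (0.12 log units; within the scatter) is therefore small. Compound 3 `CCCCCn1cc(COc2ccc(/C=C/C(=O)c3ccc4c(c3O)CCC(C)(C)O4)cc2)nn1` carries the same chain as compound 1 on a core built from the same atoms joined differently; the difference between the two cores is not broken down here. In this assay compound 3 gives 9820 nM, the lowest number of the three measured compounds, with compound 1 nearest to it and compound 2 furthest from it. Compound 4 `CCCCCCCCn1cc(COc2ccc(/C=C/C(=O)c3ccc4c(c3O)CCC(C)(C)O4)cc2)nn1` is unmeasured and stands to compound 3 as compound 2 stands to compound 1: the change is propyl in place of hydrogen on a saturated chain carbon, five bonds along the chain from an aromatic nitrogen, the same change at the same place. Among the measured compounds shown here, only one measured instance of this change exists, on the core of compound 1, where it stayed within the scatter. On that basis the step of a 1.2-fold higher number from compound 3 to compound 4 (0.09 log units; within the scatter) is expected to be small, a direct read-across of a 1.3-fold higher number from compound 1 to compound 2 (0.12 log units; within the scatter) onto compound 3, with nothing to say whether the second core answers the longer chain differently. Compound 4 is accordingly estimated at 12000 nM in this assay, with a range from 5000 nM to 30000 nM. For the measured compounds named here, the anchor for that expectation is compound 3 with 9820 nM, the only measurement on this core.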

Compound 4, half-maximal inhibitory concentration: 74100 nM
Estimate against measurement, compound 4: 6.2-fold (0.79 log units) below; the measured number lies above the stated range.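

On the core of compound 3, propyl in place of hydrogen on a saturated chain carbon, five bonds along the chain from an aromatic nitrogen, gives a 7.5-fold higher number from compound 3 to compound 4 (0.88 log units; beyond the scatter) in this assay, so the change does not carry over at the same size from one core to the other: the same change on two cores in this assay, a 1.3-fold higher number (0.12 log units; within the scatter) from compound 1 to compound 2 and a 7.5-fold higher number (0.88 log units; beyond the scatter) from compound 3 to compound 4, 5.7-fold (0.76 log units) apart, beyond the scatter of two such steps In this series, then, a step measured on the core of compound 1 is a poor guide to the same step on the core of compound 3, and the longer chain matters on the second core while on the first its step stays within the scatter. Among the compounds shown here, these two pairs do not show which difference between the cores lies behind this, nor do they support a general rule for other changes, since only a single pair of compounds stands on each core.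

For the compounds shown here, with only two chain lengths on each core, it remains open whether the number rises gradually or abruptly between them on the core of compound 3. Also open, as far as these compounds go, is how each core would answer a shorter chain such as propyl, a still longer chain, or a chain carrying an amine or a carboxylic acid.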